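Flipping one stereocentre of compound 3

The source may report more compounds than this note shows. Statements on the series, on what has been measured and on what is new or still open speak of the compounds shown alone.

In a functional assay on SK-MES-1 cells (Homo sapiens) for antiproliferative activity (on this read-out lower numbers stand for stronger inhibition and higher numbers for weaker inhibition), compound 1 `Nc1nc(=O)n([C@H]2C=C[C@@H](CO)O2)cc1Br` gives > 100000 nM, which is a limit and not a number. Compound 2 `Nc1nc(=O)n([C@H]2C=C[C@@H](CO)O2)cc1I` gives > 100000 nM, again a limit. Among the measured compounds shown here, compound 3 `O=c1[nH]c(=O)n([C@@H]2C=C[C@@H](CO)O2)cc1F` gives 10000 nM, the only true number so far. The rest of the picture is the limit of > 100000 nM in this assay, at which 2 of the 3 values shown sit, and not a measured potency.

Compound 4 `O=c1[nH]c(=O)n([C@@H]2C=C[C@H](CO)O2)cc1F` keeps everything in compound 3 except its shape: the two compounds have the same atoms and bonds and differ only in configuration as drawn: 1 of 2 stereo elements differ; a stereocentre at a saturated ring carbon is drawn S in compound 3 and R in compound 4. For the measured compounds named here, the one measured step, a step that the two limits leave unreadable from compound 1 to compound 2, swaps one halogen for another, has no readable size and says nothing about configuration. Going by the values given here, no measured step therefore bears directly on this change. Among the compounds with values here, a modest loss of activity seems the likelier outcome, with wide uncertainty, since the only firm guide is compound 3 at 10000 nM and the other two compounds show no number. The expected change is a 2.0-fold higher number from compound 3 to compound 4 (0.30 log units; within the scatter) as an estimate and no more. For compound 4 the estimated value is 20000 nM, within an expected range from 4000 nM to 100000 nM.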

Compound 4, half-maximal inhibitory concentration: 4600 nM
For compound 4 the middle estimate is 4.3-fold (0.64 log units) above the measured one; low and high end bracket the measured number.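

In this assay the switch from S to R at a saturated ring carbon gives a 2.2-fold lower number from compound 3 to compound 4 (0.34 log units; beyond the scatter) and so shows that this stereocentre registers in the read-out. Among the compounds shown here, the earlier compounds could not show this, since the only step among them has no readable size and involves a halogen swap rather than a change of shape. The step can be tied to that single stereocentre alone because of this: the fact that compounds 3 and 4 differ only in the configuration as drawn.

Going by these compounds, whether the same switch would move the number in the same direction with a methyl or chloro group in place of the fluoro group stays open. Also open, on these data alone, is what a carboxylic acid in place of the hydroxymethyl group would do, and how the drawn configuration at the second stereocentre contributes to activity.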